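The source may hold more compounds than are shown below. What is called first, only, known or untested is meant among the compounds shown, and "the series" means these compounds.

Working notes on the series. Among the compounds with values here, the compounds share the core of compound 1 `COC(=O)C1=C(C)NC(C)=C(C(=O)OCCCl)C1c1cccc([N+](=O)[O-])c1`, which in a functional assay on HEK293 cells for antagonist activity at Voltage-dependent L-type calcium channel subunit alpha-1D (Rattus norvegicus), read by FLIPR (on this read-out lower numbers stand for stronger inhibition and higher numbers for weaker inhibition), gives 22 nM, the lowest of the three numbers measured so far. Compound 2 `CCCCCOC(=O)C1=C(C)NC(C)=C(C(=O)OCC)C1c1cccc([N+](=O)[O-])c1` gives 130 nM in this assay, and compound 3 `CCOC(=O)C1=C(C)NC(C)=C(C(=O)OC=O)C1c1cccc([N+](=O)[O-])c1` gives 13900 nM. Compound 1 and compound 2 differ in more than one place, so their two values are only set side by side. Within the data shown here, the one step that reads cleanly runs from compound 2 to compound 3: a 110-fold higher number from compound 2 to compound 3 (2.03 log units; beyond the scatter). The unmeasured compound 4 `COC(=O)C1=C(C)NC(C)=C(C(=O)OC2C=CCCC2)C1c1cccc([N+](=O)[O-])c1` differs from compound 1 by cyclohex-2-en-1-yl in place of 2-chloroethyl on an oxygen next to a carbonyl group. Among the measured compounds shown here, the measured step bears on this change only indirectly: it shows that the group sitting on that oxygen can move the number by a very large amount when a formyl replaces a pentyl, but no measured pair tests a six-membered non-aromatic ring of carbon only on that oxygen, nor the loss of a 2-chloroethyl. A step of moderate size at most is therefore expected, in either direction, with a somewhat weaker result judged slightly more likely; the expected step is a 1.8-fold higher number from compound 1 to compound 4 (0.26 log units; within the scatter). Compound 4 is estimated at 40 nM, within 8 nM to 200 nM.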

Compound 4, half-maximal inhibitory concentration: 10 nM
Compound 4: middle estimate off by 4.0-fold (0.60 log units), on the high side; the measured number falls inside the stated range.
By their numbers in this assay, from the lowest: compound 4; then compound 1; then compound 2; then compound 3.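

In this assay, within the data shown here, the exchange of 2-chloroethyl for cyclohex-2-en-1-yl on an oxygen next to a carbonyl group reads as a 2.2-fold lower number from compound 1 to compound 4 (0.34 log units; beyond the scatter) and is the first step here that lowers the number, whereas the only earlier clean step, a 110-fold higher number from compound 2 to compound 3 (2.03 log units; beyond the scatter) for formyl in place of pentyl, raised it. The group on this oxygen can therefore move the number in either direction, and a six-membered non-aromatic ring of carbon only is accepted there with no loss, as is the removal of the chlorine carried by the 2-chloroethyl. Nothing at hand gives a reason for the modest gain.

The compounds shown leave open whether the double bond of the ring matters, which a saturated cyclohexyl group on the same oxygen would settle, and whether the size of the ring matters, which a cyclopentyl group would test. They also leave open how this oxygen tolerates a phenyl ring, a chain ending in an amine, or a chain ending in a carboxylic acid.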